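A few compounds are considered here, and "the series" means these few. Any claim that something is new, unique, unknown or untested is made for them only; others in the source may bear on it.

Two related compounds have been tested in an ADME assay on L1210 cells (Mus musculus) for cytotoxicity, with a stated time of 48 h; on this read-out higher numbers stand for weaker inhibition and lower numbers for stronger inhibition. Compound 1 `CC1=CCC[C@](C)(CC/C(C)=C/CC2=C(O)C(=O)C=C(N[C@@H](C(=O)O)C(C)C)C2=O)[C@@H]1C` gives 3 ug/mL, and compound 2 `C=C1[C@H](C)CCC[C@]1(C)CC/C(C)=C/CC1=C(O)C(=O)C=C(N[C@H](C(=O)O)C(C)C)C1=O` gives 4.4 ug/mL. These two values lie within the usual scatter of repeated measurements, so the numbers do not separate compound 2 from compound 1.

Compound 3 `CC1=CCC[C@](C)(CC/C(C)=C/CC2=C(O)C(=O)C=C(N[C@H](C(=O)O)C(C)C)C2=O)[C@@H]1C` has not yet been measured. It differs from compound 2 by one exchange, (a group of 9 heavy atoms (9 carbon; one six-membered non-aromatic ring of carbon only) in place of a group of 9 heavy atoms (9 carbon; one six-membered non-aromatic ring of carbon only), on a saturated chain carbon, two bonds along the chain from a double-bonded chain carbon), on a saturated chain carbon, two bonds along the chain from a double-bonded chain carbon. The two compounds have the same atoms, joined differently. The entering 1,2,3-trimethylcyclohex-3-en-1-yl group is also present in compound 1, at 3 ug/mL. Among the compounds with values here, no measured pair shows this exchange alone, so no change beyond the scatter is expected in this assay, in either direction. The expected step is a 1.2-fold lower number from compound 2 to compound 3 (0.08 log units; within the scatter). For compound 3 the estimated value is 3.7 ug/mL, with an expected range from 1.8 ug/mL to 7.5 ug/mL.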

Compound 3, half-maximal inhibitory concentration: 3.4 ug/mL
Compound 3: the middle estimate sits 1.1-fold (0.04 log units) above what was measured, and the stated range covers the measured number.
By their numbers in this assay, from the lowest: compounds 1, 3 and 2 (each within the scatter of the next).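

In this assay, placing the 1,2,3-trimethylcyclohex-3-en-1-yl group on the saturated chain carbon in place of the other ring group gives a 1.3-fold lower number from compound 2 to compound 3 (0.11 log units; within the scatter). At this position, then, moving to this isomeric ring group does not separate the compounds on this read-out. Reversing the drawn configuration at one stereocentre gives a 1.1-fold higher number from compound 1 to compound 3 (0.05 log units; within the scatter), so this assay does not distinguish the two forms, and this comparison isolates a single structural difference: the fact that compounds 1 and 3 differ only in the configuration as drawn.

The compounds shown leave open whether a more distant change at the ring position, such as a plain phenyl ring, or an amine in place of the carboxylic acid would shift the number beyond the scatter. They also cannot say whether these ring groups or configurations would differ on any other read-out.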